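The compounds below may be only part of what the source reports. "The series", "measured", "known", "first", "only" and "open" are said of these compounds alone.

Compound 1 `Cc1cc(C)cc(Cn2c(SCC(=O)Nc3ccccc3Br)nc3ccc(Cl)cc32)c1`: 174000 nM
Compound 2 `Cc1cc(C)cc(S(=O)(=O)n2c(SCC(=O)Nc3ccccc3Br)nc3ccc(Cl)cc32)c1`: 145000 nM
Compound 3 `Cc1cc(C)cc(Cn2c(SCC(=O)Nc3ccc(C)cc3Cl)nc3ccccc32)c1`: 49200 nM

These numbers come from an ADME assay on MT4 cells (Homo sapiens) for cytotoxicity; on this read-out higher numbers stand for lower toxicity in this test and lower numbers for higher toxicity in this test. Compound 1 and compound 2 differ in one place, ((3,5-dimethylphenyl)sulfonyl in place of 3,5-dimethylbenzyl on an aromatic nitrogen), and the step of a 1.2-fold lower number from compound 1 to compound 2 (0.08 log units; within the scatter). Compound 3 shares much of its build with compound 1, but the difference between the two cores is not broken down here; its number is the lowest of the three, and its gaps to compound 2 and to compound 1 both lie beyond the scatter.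

Compound 4 `Cc1cc(C)cc(S(=O)(=O)n2c(SCC(=O)Nc3ccc(C)cc3Cl)nc3ccccc32)c1` has not yet been measured in this assay. It differs from compound 3 by (3,5-dimethylphenyl)sulfonyl in place of 3,5-dimethylbenzyl on an aromatic nitrogen, the same change as that from compound 1 to compound 2. Because a 1.2-fold lower number from compound 1 to compound 2 (0.08 log units; within the scatter) stayed within the scatter, this step is expected to be small as well: a 1.1-fold lower number from compound 3 to compound 4 (0.04 log units; within the scatter). Compound 4 is therefore estimated at 45000 nM, with a likely range from 20000 nM to 100000 nM.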

Compound 4, half-maximal cytotoxic concentration: 5400 nM
For compound 4 the middle estimate is 8.3-fold (0.92 log units) above the measured one; the whole stated range lies above it.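

In this assay, putting (3,5-dimethylphenyl)sulfonyl in place of 3,5-dimethylbenzyl on the aromatic nitrogen gives a 9.1-fold lower number from compound 3 to compound 4 (0.96 log units; beyond the scatter), a clear rise in toxicity in this test. The size of this change therefore does not carry over from one core to the other: the same change on two cores in this assay, a 1.2-fold lower number (0.08 log units; within the scatter) from compound 1 to compound 2 and a 9.1-fold lower number (0.96 log units; beyond the scatter) from compound 3 to compound 4, 7.6-fold (0.88 log units) apart, beyond the scatter of two such steps. This does not show which difference between the two cores matters, and a single pair on each core gives no rule for the whole series.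

The compounds shown leave open how the bromine and chlorine substituents each contribute to the gap between the two steps. They also leave open whether another group on that nitrogen, such as a longer chain ending in an amine, would differ between the cores in the same way.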